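The source may report more compounds than this note shows. Statements on the series, on what has been measured and on what is new or still open speak of the compounds shown alone.

Working notes on the series in a functional assay on LOX IMVI cells (Homo sapiens) for cytotoxicity, read by MTT assay, with a stated time of 24 h; on this read-out higher numbers stand for weaker inhibition and lower numbers for stronger inhibition. Compound 1 `COc1cc(-c2nc(-c3ccccc3)[nH]c2-c2ccnc(NCCCNS(=O)(=O)c3ccccc3)n2)ccc1F` gives 4520 nM and compound 2 `COc1cc(-c2nc(-c3ccccc3)[nH]c2-c2ccnc(NCCCNS(=O)(=O)c3ccccc3)n2)ccc1Cl` gives 7470 nM. The two cannot be separated, as the change of halogen is a 1.7-fold higher number from compound 1 to compound 2 (0.22 log units; within the scatter). Within the data shown here, compound 3 `COc1cc(-c2nc(-c3ccccc3)[nH]c2-c2ccnc(NCCCNS(=O)(=O)c3ccc(C(F)(F)F)cc3)n2)ccc1Cl` gives 1780 nM, and this is the only change beyond the scatter so far: a 4.2-fold lower number from compound 2 to compound 3 (0.62 log units; beyond the scatter). Compound 2 therefore stands with compound 1 at the weak end of the three numbers.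

Compound 4 `O=S(=O)(NCCCNc1nccc(-c2[nH]c(-c3ccccc3)nc2-c2ccc(F)c(O)c2)n1)c1ccccc1` has 4-fluoro-3-hydroxyphenyl in place of 4-chloro-3-methoxyphenyl on an aromatic carbon of the five-membered ring: 4-fluoro-3-hydroxyphenyl in place of 4-chloro-3-methoxyphenyl on an aromatic carbon. The halogen part of this change has a direct precedent in compound 1, in the reverse direction, and that step, a 1.7-fold higher number from compound 1 to compound 2 (0.22 log units; within the scatter), suggests little movement. The trifluoromethyl step sits elsewhere on the molecule and does not bear on this change. Among the measured compounds shown here, no measured compound shows hydroxy in place of methoxy, so that part remains open and widens the range.

The expected change is small, at most near the scatter: a 1.5-fold lower number from compound 2 to compound 4 (0.17 log units; within the scatter) is the estimated step. For compound 4 the estimate is 5000 nM, with an expected range of 2000 nM to 12000 nM.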

Compound 4, half-maximal inhibitory concentration: 9580 nM
Compound 4: the middle estimate sits 1.9-fold (0.28 log units) below what was measured; the range from low to high includes it.
By their numbers in this assay, from the lowest: compound 3; then compounds 1, 2 and 4 (each within the scatter of the next, the first and the last beyond it).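

The paired change at this position, 4-fluoro-3-hydroxyphenyl in place of 4-chloro-3-methoxyphenyl, gives a 1.3-fold higher number from compound 2 to compound 4 (0.11 log units; within the scatter) in this assay, so exchanging both substituents together does not separate the two compounds. Among these compounds, with the fluoro held constant, hydrogen in place of methyl on the oxygen can be read on its own for the first time, and it gives a 2.1-fold higher number from compound 1 to compound 4 (0.33 log units; beyond the scatter), a modest step towards weaker inhibition on this single pair. No evidence at hand accounts for this step.

The compounds shown carry only hydroxy and methoxy on this ring, so the outcome with an ethoxy group or an amine in that place remains open. As far as these compounds go, it also remains open whether the trifluoromethyl gain seen in compound 3 carries over to the 4-fluoro-3-hydroxyphenyl series.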